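Ethyl benzofuran ketones: demethylation on the core

The source may report more compounds than this note shows. Statements on the series, on what has been measured and on what is new or still open speak of the compounds shown alone.

Of the compounds shown here, two carry numbers so far. Compound 1 `CCc1oc2c(OC)cccc2c1C(=O)c1ccc(OC)cc1` gives, in an assay for inhibition of solute carrier family 22 member 12 (Homo sapiens), read by scintillation counting, with a stated time of 60 min, tested at 50 uM (on this read-out higher numbers stand for more inhibition at the one concentration tested (going by the name of the read-out) and lower numbers for less inhibition), 17.2%, the lowest of the two values. Going by the values given here, compound 2 `CCc1oc2ccc(OC)cc2c1C(=O)c1ccc(O)cc1` gives in this assay 92.7%, which lies beyond the scatter above compound 1; the two compounds differ in more than one place, so their values are only noted side by side and no single step is read from them.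

Compound 3 `CCc1oc2c(O)cccc2c1C(=O)c1ccc(OC)cc1` remains to be measured in this assay. It differs from compound 1 by hydrogen in place of methyl on an oxygen on an aromatic ring. Among the compounds with values here, no measured pair isolates this change, and the free hydroxy of compound 2 sits on a different ring, so it offers no direct guide.

The expectation for compound 3 rests on compound 1 with 17.2% as the anchor. A moderate rise beyond the scatter is expected, the step of a number 22.8 percentage points higher from compound 1 to compound 3 (beyond the scatter) being the estimated change. Compound 3 is expected to give about 40%, within a range of 15% to 75%, the wide range reflecting the absence of a matched pair.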

Compound 3, a percentage reported as inhibition, at one concentration (the size of the read-out at that concentration, not a potency): 18.2%
Estimate against measurement, compound 3: 21.8 percentage points above, within the range that was stated.
By their numbers in this assay, from the lowest: compounds 1 and 3 (each within the scatter of the next); then compound 2.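

Hydrogen in place of methyl on an oxygen on an aromatic ring, read as methoxy to hydroxy, gives a number 1 percentage points higher from compound 1 to compound 3 (within the scatter) in this assay, and this is the first matched pair of the series. At this place on the core, the methoxy and the free hydroxy therefore cannot be told apart on this read-out, with compound 1 at 17.2% and compound 3 at 18.2%. No measurement at hand explains why the two compounds read alike.

The compounds shown leave open whether any group on this oxygen can move the read-out beyond the scatter, for instance a longer chain such as ethyl or propyl, or a chain ending in a carboxylic acid, and whether an amine in place of the oxygen would read differently. Going by these compounds alone, also open is what the same methoxy to hydroxy change does on the other aromatic ring of compound 1, since no matched pair isolates it.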